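A few compounds are considered here, and "the series" means these few. Any claim that something is new, unique, unknown or untested is made for them only; others in the source may bear on it.

In a functional assay on DU-145 cells (Homo sapiens) for inhibition, read by trypan blue exclusion, with a stated time of 96 h (on this read-out lower numbers stand for stronger inhibition of growth and higher numbers for weaker inhibition of growth), two compounds built on a shared core have been measured. Compound 1 (`O=C(/C(=C\c1c[nH]c2ccc(Cl)cc12)SCc1ccc(F)cc1)c1ccc(Br)cc1`) with 5-chloro-1H-indol-3-yl gives 1000 nM on this read-out, and compound 2 (`O=C(/C(=C\c1ccc(O)cc1)SCc1ccc(F)cc1)c1ccc(Br)cc1`) with 4-hydroxyphenyl at the same place gives 10000 nM as the higher of the two numbers, so compound 2 stands as the weaker growth inhibitor of the pair. Compound 3 (`O=C(/C(=C\c1ccc2ccccc2n1)SCc1ccc(F)cc1)c1ccc(Br)cc1`) differs from compound 2 at that same place (quinolin-2-yl in place of 4-hydroxyphenyl on a double-bonded chain carbon bound to a double-bonded chain carbon), with quinolin-2-yl in place of 4-hydroxyphenyl on a double-bonded chain carbon bound to a double-bonded chain carbon. Among the measured compounds shown here, on the evidence of the one measured step at that place (a 10-fold higher number from compound 1 to compound 2 (1.00 log units; beyond the scatter)), modest in size yet beyond the scatter, losing 4-hydroxyphenyl is expected to lower the number in this assay and so strengthen inhibition of growth. Quinolin-2-yl is not the group of compound 1, however, so only part of that step is expected to return. The estimated size of the change is (a 4.0-fold lower number from compound 2 to compound 3 (0.60 log units; beyond the scatter)) in that direction. For compound 3 the estimated value is 2500 nM with an expected range from 600 nM to 10000 nM in this measurement.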

Compound 3, concentration for 50% growth inhibition: 25000 nM
Estimate against measurement, compound 3: 10-fold (1.00 log units) below; measured number outside the range, above it.
By their numbers in this assay, from the lowest: compound 1; then compound 2; then compound 3.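

The new step shows that replacing 4-hydroxyphenyl at this place does not by itself improve growth inhibition in this assay: quinolin-2-yl gives a 2.5-fold higher number from compound 2 to compound 3 (0.40 log units; beyond the scatter), so the change runs the same way as the earlier loss seen on leaving 5-chloro-1H-indol-3-yl, not against it. Quinolin-2-yl has more heavy atoms than 4-hydroxyphenyl and no hydrogen-bond donor, and the full distance from the indole-bearing compound is now a 25-fold higher number from compound 1 to compound 3 (1.40 log units; beyond the scatter), which shows that among these three groups a larger aromatic group alone does not bring the number down. No measurement shown here bears on why quinolin-2-yl behaves in this way.

The compounds shown leave open whether the advantage of compound 1 lies in its indole or in its chlorine, a question that a 1H-indol-3-yl group without chlorine would address. They also leave open how a phenyl ring carrying an amine in place of the hydroxyl, or a quinolin-3-yl group with the ring attached through a different carbon, would compare at this place.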